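This account rests on a few compounds, and the source may have more. Where it says the series, first, only, none or still open, it means among the compounds named here.

Working notes on the series, taking compound 3 (`Fc1ccc(-c2ccc(-c3ccc(-c4nc5ccccc5[nH]4)cc3)cc2)cc1`) as the starting point. Among the compounds with values here, in a functional assay on MCF7 cells (Homo sapiens) for inhibition, read by sulforhodamine B assay (on this read-out lower numbers stand for stronger inhibition of growth and higher numbers for weaker inhibition of growth), compound 3 gives 36200 nM, the highest of the three numbers so far, and its gap to the other two lies beyond the scatter. The next compound is compound 4 (`COc1ccc(-c2ccc(-c3ccc(-c4nc5ccccc5[nH]4)cc3)cc2)cc1`), and its difference from compound 3 is methoxy in place of fluoro on an aromatic carbon. In words, this is methoxy in place of fluoro on an aromatic carbon, para to a large group.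

Within the data shown here, the only measured step in one place is a 1.1-fold lower number from compound 1 to compound 2 (0.05 log units; within the scatter), between compound 1 (`COc1ccc(-c2ccc(-c3ccc(-c4nc5cc(C)ccc5[nH]4)cc3)cc2)cc1OC`) and compound 2 (`COc1cc(-c2ccc(-c3ccc(-c4nc5cc(C)ccc5[nH]4)cc3)cc2)cc(OC)c1OC`). It adds a methoxy rather than replacing a fluoro, so it bears on the change only loosely. It gives no sign that a further methoxy moves the number in this series.

Compound 4 shares a methoxy group with compound 1, at 190 nM, and compound 2, at 170 nM. However, it lacks their methyl on the core, as compound 3 does. The data do not separate the methoxy from the methyl, so only part of the gap is expected to be recovered. The expected change is a 12-fold lower number from compound 3 to compound 4 (1.08 log units; beyond the scatter). For compound 4 the estimated value is 3000 nM, with an expected range from 400 nM to 20000 nM.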

Compound 4, concentration for 50% growth inhibition: 33300 nM
Compound 4: middle estimate off by 11-fold (1.05 log units), on the low side; the measured number lies above the stated range.
By their numbers in this assay, from the lowest: compounds 2 and 1 (each within the scatter of the next); then compounds 4 and 3 (each within the scatter of the next).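

In this assay, going from 4-fluorophenyl to 4-methoxyphenyl gives a 1.1-fold lower number from compound 3 to compound 4 (0.04 log units; within the scatter), so on this aromatic carbon, para to a large group, the two groups cannot be told apart by this read-out. Within the data shown here, this is the first one-place comparison that exchanges a group at this site on the core without the methyl, whereas the earlier step (a 1.1-fold lower number from compound 1 to compound 2 (0.05 log units; within the scatter)) added a methoxy to a core with the methyl and a ring that already carried methoxy groups; both steps now lie within the scatter, and in neither does a methoxy group separate the paired compounds. No measurement to hand accounts for this result.

Compound 3 and compound 4 both lack the methyl on the core that compound 1 and compound 2 carry, and no pair shown differs in that place alone, so what the methyl contributes stays open. Also open, from the compounds shown here alone, is whether an amine or a carboxylic acid on this aromatic carbon would give a number beyond the scatter of those of compound 3 and compound 4.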